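This account rests on a few compounds, and the source may have more. Where it says the series, first, only, none or still open, it means among the compounds named here.

Compound 1 `CCOc1cccnc1Nc1cccc(C)n1` gives the lowest number of the three measured compounds in an assay on Ltk cells with metabotropic glutamate receptor 5 (Homo sapiens) as the target, read by fluorescence and calcium flux (on this read-out lower numbers stand for stronger inhibition and higher numbers for weaker inhibition), with 40 nM. Compound 2 `CCOc1cccnc1Nc1cccc(C(=O)OC)n1` gives 6200 nM, and compound 3 `CCNc1cccnc1Nc1cccc(C)n1` gives 3000 nM. Two single changes to compound 1 have each moved the number a long way: a 160-fold higher number from compound 1 to compound 2 (2.19 log units; beyond the scatter), and a 75-fold higher number from compound 1 to compound 3 (1.88 log units; beyond the scatter). Compound 4 `CCOc1cc(-c2cccc(F)c2)cnc1Nc1cccc(C)n1` differs from compound 1 in another way: 3-fluorophenyl in place of hydrogen on an aromatic carbon. For the measured compounds named here, neither measured step alters this carbon, so neither bears directly on the change; they show only that the shared core responds strongly to single substitutions. Going by the values given here, with no closer precedent, the change is expected to leave the number near that of compound 1 or somewhat lower, a 1.6-fold lower number from compound 1 to compound 4 (0.20 log units; within the scatter). The estimate for compound 4 is 25 nM, within a range from 6 nM to 120 nM.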

Compound 4, half-maximal inhibitory concentration: 126 nM
Estimate against measurement, compound 4: 5.0-fold (0.70 log units) below; the whole stated range lies below it.
By their numbers in this assay, from the lowest: compound 1; then compound 4; then compound 3; then compound 2.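

At this carbon of the shared core, two atoms from the ring nitrogen, the core accepts a whole added aromatic ring with only a modest loss (a 3.2-fold higher number from compound 1 to compound 4 (0.50 log units; beyond the scatter)) and no gain. This step is smaller than either of the two earlier single changes to compound 1, which altered the ethoxy and methyl groups. So this position allows a large group to be added, although 3-fluorophenyl does not improve on hydrogen.

From the compounds shown here alone, whether a phenyl ring without its fluorine, or a small amine or methoxy group, would do better at this carbon remains open. No measurement shown explains the rise in the number.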